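Methoxy for chloro: working notes on compound 3

The compounds below may be only part of what the source reports. "The series", "measured", "known", "first", "only" and "open" are said of these compounds alone.

Values in a functional assay on T29Kt1 cells (Homo sapiens) for cytotoxicity, read by sulforhodamine B assay, with a stated time of 3 days; a lower number here means a stronger inhibitor, a higher number a weaker inhibitor:
- compound 1 `OCc1cn(Cc2ccc(Cl)cc2)c2ccccc12`: 79 nM
- compound 2 `OCc1cn(Cc2ccc(Cl)cc2)c2ccc(Cl)cc12`: 13000 nM

Of these two compounds, compound 2 has the higher number and is the weaker inhibitor in this assay. The unmeasured compound 3 `COc1ccc2c(c1)c(CO)cn2Cc1ccc(Cl)cc1` has methoxy in place of chloro on an aromatic carbon.

For the measured compounds named here, only one measured step bears on this change. Chloro in place of hydrogen on that same aromatic carbon gave a large step, a 160-fold higher number from compound 1 to compound 2 (2.22 log units; beyond the scatter). Going by the values given here, no compound with methoxy has been measured, so the data give no direct size for the change to compound 3. Among the compounds with values here, the large step shows only that the group on this carbon can shift the number widely. A step beyond the scatter towards a lower number is therefore expected, recovering only part of the distance to compound 1 at 79 nM. The estimate for compound 3 is an expected 2500 nM, with an expected range of 250 nM to 20000 nM. This estimate means an expected 5.2-fold lower number from compound 2 to compound 3 (0.72 log units; beyond the scatter).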

Compound 3, half-maximal inhibitory concentration: 12500 nM
Estimate against measurement, compound 3: 5.0-fold (0.70 log units) below; measured number inside the range.
By their numbers in this assay, from the lowest: compound 1; then compounds 3 and 2 (each within the scatter of the next).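

In (this assay), methoxy in place of chloro on this aromatic carbon gives (a 1.0-fold lower number from compound 2 to compound 3 (0.02 log units; within the scatter)), so the two groups cannot be told apart here, even though chloro has 1 heavy atom and 0 hydrogen-bond acceptors, and methoxy has 2 heavy atoms and 1 hydrogen-bond acceptor. Methoxy in place of hydrogen gives (a 160-fold higher number from compound 1 to compound 3 (2.20 log units; beyond the scatter)), a large step in the same direction as the one for chloro (a 160-fold higher number from compound 1 to compound 2 (2.22 log units; beyond the scatter)), so in the compounds shown both groups on this carbon separate clearly from compound 1, which carries hydrogen there. No measurement at hand explains why the two groups fall together or why both stand so far from hydrogen.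

The compounds shown leave open whether fluoro, methyl, an amine or a carboxylic acid on this carbon would stay with compound 2 and compound 3 or come back towards compound 1 (79 nM). Also open, as far as these compounds go, is whether the large step belongs to this carbon alone, since these compounds vary in this one place only.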